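Selenocyanate tether shortening on the shared core

The source may hold more compounds than are shown below. What is called first, only, known or untested is meant among the compounds shown, and "the series" means these compounds.

Compound 3 `COc1ccc(N(C)c2nc(C)nc3ccccc23)cc1C[Se]C#N` gives 277 nM in a functional assay on LoVo cells (Homo sapiens) for inhibition, read by MTT assay, with a stated time of 48 h; on this read-out higher numbers stand for weaker inhibition and lower numbers for stronger inhibition. Within the three measured compounds it holds the lowest number, and both steps toward it lie beyond the scatter: compound 1 `COc1ccc(N(C)c2nc(C)nc3ccccc23)cc1C(=O)NCC[Se]C#N` gives 561 nM, compound 2 `COc1ccc(N(C)c2nc(C)nc3ccccc23)cc1C(=O)OCCC[Se]C#N` gives 854 nM, and the steps were a 2.0-fold lower number from compound 1 to compound 3 (0.31 log units; beyond the scatter) and a 3.1-fold lower number from compound 2 to compound 3 (0.49 log units; beyond the scatter). The step from compound 1 to compound 2, a 1.5-fold higher number from compound 1 to compound 2 (0.18 log units; within the scatter), stays within the scatter.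

Compound 4 `COc1ccc(N(C)c2nc(C)nc3ccccc23)cc1[Se]C#N` differs from compound 3 by a group of 3 heavy atoms (1 carbon, 1 nitrogen, 1 selenium; no ring) in place of a group of 4 heavy atoms (2 carbon, 1 nitrogen, 1 selenium; no ring), on an aromatic carbon, on an aromatic carbon ortho to a methoxy group and meta to a large group. Going by the values given here, no measured step removes a single carbon from the tether this way; the steps that bear on it, a 2.0-fold lower number from compound 1 to compound 3 (0.31 log units; beyond the scatter) and a 3.1-fold lower number from compound 2 to compound 3 (0.49 log units; beyond the scatter), each replaced a longer tether with the shorter one and each lowered the number modestly. The step from compound 3 to compound 4 is therefore expected to be small, a 1.1-fold lower number from compound 3 to compound 4 (0.04 log units; within the scatter), with a slight lean toward a lower number but plausibly within the scatter. Compound 4 is estimated at 250 nM in this assay, with a range of 100 nM to 700 nM.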

Compound 4, half-maximal inhibitory concentration: 73 nM
Beside the measured number, compound 4's estimate is 3.4-fold (0.53 log units) above it, and the stated range ends above it.
By their numbers in this assay, from the lowest: compound 4; then compound 3; then compounds 1 and 2 (each within the scatter of the next).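

Placing the selenocyanate directly on the aromatic carbon, ortho to a methoxy group, gives a further drop in this assay (a 3.8-fold lower number from compound 3 to compound 4 (0.58 log units; beyond the scatter)), so removing the last tether carbon still changes the number at this position. Compound 4 now lies beyond the scatter of both longer tethers (a 7.7-fold lower number from compound 1 to compound 4 (0.89 log units; beyond the scatter); a 12-fold lower number from compound 2 to compound 4 (1.07 log units; beyond the scatter)), and across the series the shorter attachment goes with the lower number, although compound 1 and compound 2 remain within the scatter of each other. Nothing measured here explains why the directly attached group gives the lowest number.

On these data alone, whether selenium and the nitrile are both needed remains open; a thiocyanate, a plain nitrile or a methylseleno group on the same aromatic carbon would separate them. As far as these compounds go, whether the order holds in other cell lines also remains open.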